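A few compounds are considered here, and "the series" means these few. Any claim that something is new, unique, unknown or untested is made for them only; others in the source may bear on it.

In a functional assay on a cell-free system (plasma) for inhibition of thromboxane A2 receptor (Homo sapiens), read by turbidimetry (a higher number here means a weaker inhibitor, a lower number a stronger inhibitor), the three measured compounds stand as follows:
compound 1 `O=C(O)CCC/C=C\CC1=CCC[C@@H]1NS(=O)(=O)c1ccccc1` gives 2300 nM;
compound 2 `O=C(O)CCC/C=C\C[C@H]1[C@H](F)CC[C@@H]1NS(=O)(=O)c1ccccc1` gives 1100 nM;
compound 3 `O=C(O)CCC/C=C\CC1=CCC[C@@H]1NS(=O)(=O)c1ccccc1[N+](=O)[O-]` gives 680 nM.

Compound 3 arises from compound 1 by a single change, (nitro in place of hydrogen on an aromatic carbon), and that change brought a 3.4-fold lower number from compound 1 to compound 3 (0.53 log units; beyond the scatter). Compound 2 shares the sulfonamide side with compound 1 but carries a different core; the difference between the two cores is not broken down here. Compound 2 and compound 3 lie within the usual scatter of each other.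

Compound 4 `O=C(O)CCC/C=C\C[C@H]1[C@H](F)CC[C@@H]1NS(=O)(=O)c1ccccc1[N+](=O)[O-]` has not yet been measured. It arises from compound 2 by the same change, (nitro in place of hydrogen on an aromatic carbon), on the same place of the ring. Compound 4 is expected to show a 3.3-fold lower number from compound 2 to compound 4 (0.52 log units; beyond the scatter) in this assay. This expectation rests on the step of a 3.4-fold lower number from compound 1 to compound 3 (0.53 log units; beyond the scatter) and on the value of compound 2, 1100 nM. Compound 4 is therefore estimated at 330 nM, with a likely range from 150 nM to 750 nM.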

Compound 4, half-maximal inhibitory concentration: 1800 nM
Compound 4: middle estimate off by 5.5-fold (0.74 log units), on the low side; the measured number lies above the stated range.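

In this assay the step from hydrogen to nitro on the core of compound 2 gave a 1.6-fold higher number from compound 2 to compound 4 (0.21 log units; within the scatter) and so did not repeat the lower number seen on the core of compound 1. With one pair on each core, this does not show which feature of the two cores matters, or how the change would behave on any further core. What it does show is that the step measured on one core cannot simply be carried to the other in this series: the same change on two cores in this assay, a 3.4-fold lower number (0.53 log units; beyond the scatter) from compound 1 to compound 3 and a 1.6-fold higher number (0.21 log units; within the scatter) from compound 2 to compound 4, 5.5-fold (0.74 log units) apart, beyond the scatter of two such steps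

The compounds shown leave open whether a nitrile or an amine in place of nitro would also part ways between the two cores. They also leave open whether the fluorine on the core of compound 2 is what separates the two results.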